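This account rests on a few compounds, and the source may have more. Where it says the series, first, only, none or still open, it means among the compounds named here.

Measured compounds so far:

Compound 1 `Cc1[nH]nc(N)c1-c1ccc(Cl)c(Cl)c1`: in an assay on Sf9 cells for inhibition of inhibitor of nuclear factor kappa-B kinase subunit epsilon (Homo sapiens), read by ADP-Glo, with a stated time of 60 min (a higher number here means a weaker inhibitor, a lower number a stronger inhibitor), compound 1 gives > 100000 nM, which is a limit of the assay and not a number.
Compound 2 `Cc1c(-c2ccc(Cl)c(Cl)c2)c(N)nn1C`: in this assay compound 2 gives > 100000 nM, again a limit of the assay.
Compound 3 `Cc1[nH]nc(NC(=O)c2ccccn2)c1-c1ccc(Cl)c(Cl)c1`: in this assay compound 3 gives > 100000 nM, also a limit of the assay.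

Compound 3 therefore stands at the limit, together with every other value shown (the limit of > 100000 nM in this assay, at which 3 of the 3 values shown sit). Among the compounds with values here, the only single-point step among the measured compounds, a step that the two limits leave unreadable from compound 1 to compound 2, runs between two limits and its size cannot be read.

Compound 4 `Cc1[nH]nc(NC(=O)C(F)(F)F)c1-c1ccc(Cl)c(Cl)c1` differs from compound 3 by trifluoromethyl in place of pyridin-2-yl on a carbonyl carbon. Within the data shown here, no measured step touches the group on the carbonyl carbon, so nothing among the data bears directly on this change; the one step that exists is unreadable in size. With all three values sitting at the limit (the limit of > 100000 nM in this assay, at which 3 of the 3 values shown sit), the step from compound 3 to compound 4 is expected to be none that can be read, a number no higher from compound 3 to compound 4 (the limit leaves the size open). Compound 4 is accordingly expected to remain at or near the limit, estimated at 100000 nM, with a range from 30000 nM to 300000 nM.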

Compound 4, half-maximal inhibitory concentration: > 100000 nM
Compound 4: only a limit was reported; the forecaster's own chance of this, stated with the estimate: 85%; the middle value sits exactly at the limit.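

In this assay compound 4 gives > 100000 nM, which is a limit of the assay and not a number. The steps to compound 4 from compound 3 and from compound 1 cannot be read. The compounds shown leave open which change to the shared core, if any, would give a readable value: the limit of > 100000 nM in this assay, at which 4 of the 4 values shown sit.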